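This account rests on a few compounds, and the source may have more. Where it says the series, first, only, none or still open, it means among the compounds named here.

Measured so far in a toxicity assay on THP-1 cells (Homo sapiens) for inhibition; on this read-out lower numbers stand for higher toxicity in this test and higher numbers for lower toxicity in this test:
- compound 1 `Cn1c(-c2ccc(C#N)cc2)cnc1NC(=O)c1ccc(F)cc1` gives > 50000 nM, a limit of this assay rather than a number.
- compound 2 `Cn1c(-c2ccccc2)cnc1NC(=O)c1cccc(Br)c1` gives > 50000 nM, likewise only a limit.
- compound 3 `Cn1c(-c2ccc(C#N)cc2)cnc1NC(=O)c1ncc[nH]1` gives > 100000 nM, again a limit.

Compound 1 therefore has no numerical position on this read-out; its value is a limit, and the two further values shown are limits as well. Going by the values given here, the single one-place step, a step that the two limits leave unreadable from compound 1 to compound 3, cannot be read because both ends sit at limits, the limit of > 50000 nM in this assay, at which 2 of the 3 values shown sit, and (the limit of > 100000 nM in this assay, at which 1 of the 3 values shown sits). Compound 2 is not one step from compound 1; its value shows only that it, too, did not reach measurable toxicity.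

The unmeasured compound 4 `Cn1c(-c2cccc(Cl)c2)cnc1NC(=O)c1ccc(F)cc1` differs from compound 1 by 3-chlorophenyl in place of 4-cyanophenyl on an aromatic carbon. No measured step touches this position, so none bears on it directly; all that can be said is that every compound shown, with aryl or azolyl variation at the amide, stays at a limit in this assay. Compound 4 is therefore expected to stay at a limit as well, with an expected step that the limit leaves unreadable from compound 1 to compound 4 that is not beyond the scatter. The estimate for compound 4 is 80000 nM, between 30000 nM and 300000 nM.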

Compound 4, half-maximal cytotoxic concentration: > 50000 nM
Compound 4: no number, only a limit (the forecaster's own chance of this, stated with the estimate: 85%); the middle value is on the limit's open side.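

Compound 4, like compound 1, sits at a limit in this assay, so no step can be read between compound 1 and compound 4. The compounds shown leave open at what concentration, if any, toxicity appears, and whether 3-chlorophenyl and 4-cyanophenyl differ there.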